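The source may report more compounds than this note shows. Statements on the series, on what has been measured and on what is new or still open speak of the compounds shown alone.

Measured so far:
Compound 1 `CCOC(=O)N(Cc1ccccc1Oc1ccccc1)[C@H]1CCNC1` gives 1900 nM in an assay on HEK293 cells for inhibition of sodium-dependent dopamine transporter (Homo sapiens); a lower number here means a stronger inhibitor, a higher number a weaker inhibitor.
Compound 2 `CCOC(=O)N(Cc1ccccc1C(C)C)[C@H]1CCNC1` gives 3340 nM in this assay.
Compound 3 `CCOC(=O)N(Cc1ccccc1SC)[C@H]1CCNC1` has no reported number in this assay "not determined" (no result reported).

Compound 1 carries the lowest of the two numbers shown, with compound 2 nearest to it; the step of a 1.8-fold higher number from compound 1 to compound 2 (0.24 log units; within the scatter) lies within the scatter, so these two values cannot be told apart. Compound 4 `CS(=O)(=O)N(Cc1ccccc1Oc1ccccc1)[C@H]1CCNC1` differs from compound 1 by methylsulfonyl in place of ethoxycarbonyl on an amine nitrogen. Going by the values given here, the only measured step changes the group on the aromatic carbon, while the change here sits on the amine nitrogen; no measured pair therefore bears directly on this step, and its size cannot be read from the data. With nothing pointing up or down, the expectation is a step of a 1.1-fold higher number from compound 1 to compound 4 (0.02 log units; within the scatter) that stays within the scatter, and the range given is wide to reflect this. Compound 4 is estimated at 2000 nM, expected between 600 nM and 7000 nM.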

Compound 4, inhibition constant: 2550 nM
Beside the measured number, compound 4's estimate is 1.3-fold (0.11 log units) below it; the measured number falls inside the stated range.
By their numbers in this assay, from the lowest: compounds 1, 4 and 2 (each within the scatter of the next).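

Going by these compounds alone, compound 4 is the first measured change on the amine nitrogen, as the earlier step changed only the group on the aromatic carbon. Methylsulfonyl in place of ethoxycarbonyl gives a 1.3-fold higher number from compound 1 to compound 4 (0.13 log units; within the scatter) in this assay, so at this nitrogen the two groups cannot be told apart, with phenoxy kept on the aromatic carbon. Nothing available explains why the two groups read alike.

Still open, as far as these compounds go, is whether other groups on this nitrogen, such as acetyl, a longer carbamate like butoxycarbonyl, or a plain hydrogen giving a free amine, would also leave the number within the scatter. From the compounds shown here alone, it is equally open whether methylsulfonyl would give the same outcome with isopropyl on the aromatic carbon in place of phenoxy.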